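Series notes: aryl substituent on the shared core

The compounds below may be only part of what the source reports. "The series", "measured", "known", "first", "only" and "open" are said of these compounds alone.

Measured so far:
compound 1 `CCCCCc1cc(Nc2ccc(OC)cc2)cc(=O)o1` — 4.93 uM
compound 2 `COc1ccc(Nc2cc(-c3ccccc3)oc(=O)c2)cc1` — 0.079 uM

Within the data shown here, in a functional assay on SK-BR-3 cells (Homo sapiens) for cytotoxicity, read by MTT assay, with a stated time of 72 h (a lower number here means that less compound is needed, a higher number that more compound is needed for the effect), compound 2 gives 0.079 uM and stands lowest of the two numbers so far; the nearest, compound 1, lies well above it. Among the measured compounds shown here, the one measured step on the shared core is a 62-fold lower number from compound 1 to compound 2 (1.80 log units; beyond the scatter), a large move obtained by placing an aromatic ring where a chain had been.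

Compound 3 `COc1ccc(Nc2cc(-c3ccco3)oc(=O)c2)cc1` is not yet measured. It differs from compound 2 in one place: furan-2-yl in place of phenyl on an aromatic carbon. The furan-2-yl ring sits next to the ring oxygen of the core, meta to a group of 1 heavy atom and meta to a group of 9 heavy atoms, exactly where the phenyl of compound 2 stood.

For the measured compounds named here, no measured step exchanges one aromatic ring for another; the only step, from compound 1 to compound 2, swaps a chain for a ring, so it bears on compound 3 only in showing that an aromatic ring at this position is compatible with a low number. An exchange of phenyl for a five-membered aromatic ring is expected to move the number little, and a step of a 1.9-fold higher number from compound 2 to compound 3 (0.28 log units; within the scatter) is estimated. For compound 3 in this assay the expected value is 0.15 uM, with a range of 0.04 uM to 0.6 uM.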

Compound 3, concentration for half-maximal effect: 1.76 uM
The estimate for compound 3 lay 12-fold (1.07 log units) below the measured number; the measured number lies above the stated range.
By their numbers in this assay, from the lowest: compound 2; then compound 3; then compound 1.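

In this assay the position next to the ring oxygen proves sensitive to the identity of the aromatic ring, not only to the presence of one: the exchange of phenyl for furan-2-yl gives a 22-fold higher number from compound 2 to compound 3 (1.35 log units; beyond the scatter) as its result. Measured against the pentyl chain, furan-2-yl retains only a small part of what phenyl achieves, with a 2.8-fold lower number from compound 1 to compound 3 (0.45 log units; beyond the scatter) as the step for the five-membered ring and a 62-fold lower number from compound 1 to compound 2 (1.80 log units; beyond the scatter) as the step for phenyl, so among these three compounds both aromatic rings give a lower number than pentyl, but they are far from interchangeable. Among these compounds, no available evidence bears on why this exchange moves the number so far.

The step from compound 2 to compound 3 changes ring size, atom count and hetero atom content at once, so the compounds shown do not separate these changes from one another. A thiophene-2-yl group would keep the five-membered ring without the oxygen and a pyridin-3-yl group would keep the six-membered ring with a nitrogen, and either could show which of these changes tracks with the higher number.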